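This account rests on a few compounds, and the source may have more. Where it says the series, first, only, none or still open, it means among the compounds named here.

Series notes, antiproliferative read-out. Compound 1 `Cc1ccc2nc(C(=O)Nc3c(F)cc(-c4cccc(F)c4)cc3F)c(C)c(O)c2c1` gives in a functional assay on A-375 cells (Homo sapiens) for antiproliferative activity, read by MTT assay, with a stated time of 24 h, tested at 3.7 ug/mL (a lower number here means a weaker effect, a higher number a stronger effect of the compound at the concentration tested), a value of 16.2%. Compound 2 `COc1ccc2nc(C(=O)Nc3ccc(-c4ccccc4)cc3)c(C)c(O)c2c1`, which carries a methoxy group and a different amide portion, gives in this assay 27.2%. Compound 3 `Cc1ccc2nc(C(=O)Nc3c(F)cc(-c4cccc(F)c4)cc3F)c(C)c(C(=O)O)c2c1` gives in this assay 9.25%. For the measured compounds named here, on these three numbers compound 3 stands lowest; the nearest number is that of compound 1, and the single step of a number 7 percentage points lower from compound 1 to compound 3 (within the scatter) lies within the scatter, so the two cannot be ordered. The number of compound 2 lies beyond the scatter above that of compound 3.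

Compound 4 `CCOc1ccc2nc(C(=O)Nc3c(F)cc(-c4cccc(F)c4)cc3F)c(C)c(C(=O)O)c2c1` is the next member of the series, still unmeasured. It differs from compound 3 in one place: ethoxy in place of methyl on an aromatic carbon. Going by the values given here, no measured step in this set exchanges methyl for ethoxy, or any alkyl group for an alkoxy group, on the same amide and core; compound 2 carries a methoxy group but also a different amide portion, so its value shows only that a methoxy analogue can give a number of that size, not the size of this step. Among the compounds with values here, the only step recorded, the one within the scatter between compound 1 and compound 3, does not touch this position. Within the data shown here, with no bearing step, the expectation for compound 4 in this assay is a change of a number 2.8 percentage points higher from compound 3 to compound 4 (within the scatter), that is none beyond the scatter. Compound 4 is therefore estimated at 12%, with a range of 3% to 26%.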

Compound 4, a percentage reported as inhibition, at one concentration (the size of the read-out at that concentration, not a potency): 35.2%
Beside the measured number, compound 4's estimate is 23.2 percentage points below it; measured number outside the range, above it.
By their numbers in this assay, from the lowest: compounds 3 and 1 (each within the scatter of the next); then compounds 2 and 4 (each within the scatter of the next).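

In this assay the position on the aromatic carbon, meta to a fused ring and para to a fused ring, proves responsive: a number 26 percentage points higher from compound 3 to compound 4 (beyond the scatter), with ethoxy in place of methyl on an otherwise unchanged amide and core. For the compounds shown here, the only earlier step, a number 7 percentage points lower from compound 1 to compound 3 (within the scatter), concerned a different aromatic carbon and stayed within the scatter, so this is the first exchange in one place that moves this read-out beyond it. The exchange adds an oxygen and lengthens the group at once, this pair cannot separate the two, and nothing measured here offers a reason for the step.

A methoxy group, a propoxy chain or an amine at this position, on the same amide and core, would show whether the step goes with the oxygen or with the chain length. Also open, from the compounds shown here alone, is whether the step carries over to the hydroxy form seen in compound 1, and whether it holds at other concentrations, as this read-out gives a size at one concentration and not a potency.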